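Sulfonyl substituents on the urea series: compound 4

The source may report more compounds than this note shows. Statements on the series, on what has been measured and on what is new or still open speak of the compounds shown alone.

Compound 1 `O=C(NCc1ccncc1)Nc1ccc(S(=O)(=O)c2ccccc2Cl)cc1` gives 79 nM in an assay on isolated protein for activation of Nicotinamide phosphoribosyltransferase (Homo sapiens); a higher number here means that more compound is needed for the effect, a lower number that less compound is needed. Compound 2 `NS(=O)(=O)c1ccc(NC(=O)NCc2ccncc2)cc1` gives 14300 nM in this assay, and compound 3 `CN(C1CCCC1)S(=O)(=O)c1ccc(NC(=O)NCc2ccncc2)cc1` gives 123 nM. Compound 3 thus holds the second highest of the three numbers: its nearest neighbour is compound 1, with a 1.6-fold higher number from compound 1 to compound 3 (0.19 log units; within the scatter), and the furthest is compound 2, with a 120-fold lower number from compound 2 to compound 3 (2.07 log units; beyond the scatter).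

Compound 4 `CCN(CC)S(=O)(=O)c1ccc(NC(=O)NCc2ccncc2)cc1` differs from compound 3 in one place: diethylamino in place of cyclopentyl(methyl)amino on a sulfonyl sulfur. Among the compounds with values here, two measured steps touch the same position. The step from compound 2 to compound 3, a 120-fold lower number from compound 2 to compound 3 (2.07 log units; beyond the scatter), shows that replacing the bare amino group on the sulfonyl sulfur with a group that carries no hydrogen-bond donor changes the number a great deal; the step from compound 1 to compound 3, a 1.6-fold higher number from compound 1 to compound 3 (0.19 log units; within the scatter), shows that two such groups without donors sit close together. Diethylamino, like cyclopentyl(methyl)amino, brings no hydrogen-bond donor and no acceptor, so the change from compound 3 to compound 4 is expected to resemble the second of these steps rather than the first, that is, no step beyond the scatter, a 1.2-fold higher number from compound 3 to compound 4 (0.09 log units; within the scatter). Compound 4 is therefore estimated at 150 nM in this assay, within 60 nM to 400 nM.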

Compound 4, half-maximal effective concentration: 384 nM
Compound 4: the middle estimate sits 2.6-fold (0.41 log units) below what was measured; the range from low to high includes it.
By their numbers in this assay, from the lowest: compounds 1 and 3 (each within the scatter of the next); then compound 4; then compound 2.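

In this assay, the sulfonyl substituents that carry no hydrogen-bond donor are not interchangeable: diethylamino is separated from cyclopentyl(methyl)amino by a step beyond the scatter (a 3.1-fold higher number from compound 3 to compound 4 (0.49 log units; beyond the scatter)), although both groups count 0 hydrogen-bond donors and 0 hydrogen-bond acceptors, and it is also separated from the 2-chlorophenyl group (a 4.9-fold higher number from compound 1 to compound 4 (0.69 log units; beyond the scatter)), whereas compound 3 and compound 1 lie within the scatter of each other. Most of the gain over the amino group nevertheless survives with diethylamino (a 37-fold lower number from compound 2 to compound 4 (1.57 log units; beyond the scatter)), so this position tolerates a finer adjustment on top of one large effect, with the open diethylamino group lying between the amino group and the other two substituents. No data at hand bear on why diethylamino and cyclopentyl(methyl)amino differ.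

Diethylamino differs from cyclopentyl(methyl)amino both in lacking a ring and in its number of heavy atoms, so the compounds shown do not separate these two features. A pyrrolidin-1-yl or piperidin-1-yl group on the sulfonyl sulfur, or a cyclopentylamino group without the methyl, would pull them apart.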